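Compound 3 to compound 4: same atoms, joined differently

The source may hold more compounds than are shown below. What is called first, only, known or untested is meant among the compounds shown, and "the series" means these compounds.

Three measured compounds share one core and differ in the group on the amide-type nitrogen. In a physicochemical assay for solubility, read by spectrophotometry, measured as kinetic solubility, at pH 8, tested at 500 uM (on this read-out higher numbers stand for higher solubility and lower numbers for lower solubility), compound 1 `CN1CCC(NC(=O)c2ccncc2Nc2cc(-c3ccc4ccn(C)c4c3)c3nccnc3c2)CC1` gives 246 ug/mL, and compound 2 `CC(=O)N1CCC(NC(=O)c2ccncc2Nc2cc(-c3ccc4ccn(C)c4c3)c3nccnc3c2)CC1` gives 213 ug/mL. Exchanging methyl for acetyl on the ring nitrogen gives a 1.2-fold lower number from compound 1 to compound 2 (0.06 log units; within the scatter). Compound 3 `CN1CCC(NC(=O)c2ccncc2Nc2cc(-c3ccc4ccn(C)c4c3)c3nccnc3c2)CC1=O` is the lowest of the three at 48 ug/mL, and the steps leading to it are a 5.1-fold lower number from compound 1 to compound 3 (0.71 log units; beyond the scatter) and a 4.4-fold lower number from compound 2 to compound 3 (0.65 log units; beyond the scatter).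

The next compound, compound 4 `CC(=O)N1CC(CNC(=O)c2ccncc2Nc2cc(-c3ccc4ccn(C)c4c3)c3nccnc3c2)C1`, is built from the same atoms as compound 3, joined differently: (1-acetylazetidin-3-yl)methyl in place of 1-methyl-2-oxopiperidin-4-yl on an amide-type nitrogen. In words, this puts (1-acetylazetidin-3-yl)methyl in place of 1-methyl-2-oxopiperidin-4-yl on an amide-type nitrogen. Going by the values given here, no measured compound carries the four-membered ring, so any forecast is an analogy and an uncertain one. The closest guide is compound 2, which also has an acetyl on a ring nitrogen and reads 213 ug/mL. The 1-methyl-2-oxopiperidin-4-yl group appears only in compound 3, and compound 4 gives it up. In this assay a modest upward move is therefore expected, and the estimated change is a 3.3-fold higher number from compound 3 to compound 4 (0.52 log units; beyond the scatter). Compound 4 is expected to read about 160 ug/mL, with an estimated range from 65 ug/mL to 265 ug/mL.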

Compound 4, solubility: 252 ug/mL
For compound 4 the middle estimate is 1.6-fold (0.20 log units) below the measured one, and the stated range covers the measured number.
By their numbers in this assay, from the lowest: compound 3; then compounds 2, 1 and 4 (each within the scatter of the next).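

Compound 3 and compound 4 have the same counts under their changed groups, yet in this assay rearranging those atoms on the amide-type nitrogen moves the reading clearly (a 5.3-fold higher number from compound 3 to compound 4 (0.72 log units; beyond the scatter)), so the atom count of the group does not by itself set the number at this position. Going by these compounds alone, compound 4 also sits within the scatter of both other compounds (a 1.2-fold higher number from compound 2 to compound 4 (0.07 log units; within the scatter); a 1.0-fold higher number from compound 1 to compound 4 (0.01 log units; within the scatter)), which leaves compound 3, the only one carrying 1-methyl-2-oxopiperidin-4-yl, as the single compound apart from the rest of this small set. The data shown offer no measurement that explains this difference.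

From the compounds shown here alone, with only four compounds, it remains open whether the low reading belongs to the carbonyl inside the six-membered ring or to some other feature of the 1-methyl-2-oxopiperidin-4-yl group. Going by these compounds, it is also open how the reading would respond to (1-methylazetidin-3-yl)methyl, which would pair the four-membered ring with a methyl in place of the acetyl, or to a group of another kind, such as a carboxylic acid.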